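Compound 3 follows compound 2 with a changed side chain

The compounds below may be only part of what the source reports. "The series", "measured", "known", "first", "only" and "open" are said of these compounds alone.

compound 1 `CS(=O)(=O)Nc1ccc2c(c1)S(=O)(=O)N=C(c1c(O)c(-c3ccc(Cl)s3)nn(CCC3CC3)c1=O)N2` gives > 33000 nM
compound 2 `CCC(C)(C)Cn1nc(-c2cccs2)c(O)c(C2=NS(=O)(=O)c3cc(NS(C)(=O)=O)ccc3N2)c1=O` gives > 1000 nM

In an ADME assay on Huh-7 cells (Homo sapiens) for cytotoxicity, with a stated time of 72 h (on this read-out lower numbers stand for higher toxicity in this test and higher numbers for lower toxicity in this test), compound 2 gives > 1000 nM as a limit and not a number. Compound 1 also gives only a limit, > 33000 nM and the expectation here leans on it. Compound 3 `CS(=O)(=O)Nc1ccc2c(c1)S(=O)(=O)N=C(c1c(O)c(-c3cccs3)nn(CCC3CC3)c1=O)N2` is still unmeasured. It differs from compound 2 by cyclopropylmethyl in place of 1,1-dimethylpropyl on a saturated chain carbon bound to an aromatic nitrogen and so carries cyclopropylmethyl in place of 1,1-dimethylpropyl on a saturated chain carbon bound to an aromatic nitrogen. A rise toward lower toxicity is expected, with the estimated step that the limit leaves unreadable from compound 2 to compound 3 as its size. For compound 3 the estimate is 20000 nM as the expected middle, with 4000 nM and 60000 nM as the expected ends of its range.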

Compound 3, half-maximal cytotoxic concentration: > 33000 nM
Compound 3: a limit, no number; the forecaster's own chance of this, stated with the estimate: 70%; middle value at least 1.6-fold (0.21 log units) away from the limit.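

Going by these compounds alone, compound 1, compound 2 and compound 3 all give only limits, so no step to compound 3 can be read. As far as these compounds go, the actual half-maximal cytotoxic concentration of each compound, and whether either change shifts it, remain open.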